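The compounds below may be only part of what the source reports. "The series", "measured", "known", "first", "only" and "open" are said of these compounds alone.

Working notes on the series. Compound 1 `Cc1c(Cl)cccc1CCCCOc1ccc(C#Cc2cccc3c(CCC(=O)O)c(C)n(CCCCC(=O)O)c23)cc1` gives 4.6 10^-6 cm/s in a physicochemical assay for permeability, using PAMPA, with a stated time of 4 h, at pH 7.4, tested at 50 uM; a higher number here means that the compound crosses the layer faster, a lower number that the compound crosses the layer more slowly. Compound 2 `Cc1c(F)cccc1CCCCOc1ccc(/C=C/c2cccc3c(CCCC(=O)O)c(C)n(CC(=O)O)c23)cc1` gives 1.5 10^-6 cm/s in this assay. Compound 3 `Cc1c(F)cccc1CCCCOc1ccc(/C=C/c2cccc3c(CCCC(=O)O)cn(CC(=O)O)c23)cc1` reports only a limit in this assay, < 0.05 10^-6 cm/s, which is a limit of the measurement and not a number (the limit of < 0.05 10^-6 cm/s in this assay, at which 1 of the 3 values shown sits). The one measured single-point step, an at least 30-fold lower number from compound 2 to compound 3 (1.47 log units; beyond the scatter), is large and arises from hydrogen in place of methyl on an aromatic carbon; in this assay compound 3 therefore stands at the bottom of the numbers shown.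

Compound 4 `O=C(O)CCCc1cn(CC(=O)O)c2c(/C=C/c3ccc(OCCCCOc4ccccc4)cc3)cccc12` is not yet measured. It differs from compound 3 by phenoxy in place of 3-fluoro-2-methylphenyl on a saturated chain carbon, four bonds along the chain from an oxygen on an aromatic ring. Among the compounds with values here, no measured step in this set touches that outer ring, so the step from compound 2 to compound 3 gives no direction for this exchange, and no step beyond the scatter is expected from it. Compound 3 sits at a limit, so the expectation is that compound 4 will again sit at or near that limit. For compound 4 the estimate in this assay is 0.05 10^-6 cm/s, with a range from 0.02 10^-6 cm/s to 0.2 10^-6 cm/s. The expected step is a number no lower from compound 3 to compound 4 (the limit leaves the size open).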

Compound 4, apparent permeability: < 0.05 10^-6 cm/s
Compound 4: only a limit was reported; the forecaster's own chance of this, stated with the estimate: 60%; the middle value lies on the limit itself.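

Compound 3 and compound 4 both report only a limit in this assay, not a number, so no step can be read between them: the limit of < 0.05 10^-6 cm/s in this assay, at which 2 of the 4 values shown sit.

The compounds shown leave open the size and direction of the exchange of 3-fluoro-2-methylphenyl for phenoxy in this assay.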